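The source may hold more compounds than are shown below. What is called first, only, known or untested is meant among the compounds shown, and "the series" means these compounds.

In a functional assay on SGC-7901 cells (Homo sapiens) for cytotoxicity, read by MTT assay, with a stated time of 48 h (on this read-out lower numbers stand for stronger inhibition and higher numbers for weaker inhibition), compound 1 `COc1ccc(-c2nnc(SCCn3c([N+](=O)[O-])cnc3C)o2)cc1` gives 10200 nM, compound 2 `Cc1ncc([N+](=O)[O-])n1CCSc1nnc(-c2ccccc2N)o1` gives 35100 nM and compound 3 `Cc1ncc([N+](=O)[O-])n1CCSc1nnc(-c2ccccc2F)o1` gives 33700 nM. Compound 3 thus cannot be told apart from compound 2, and both show weaker inhibition than compound 1.

The next compound is compound 4 `Cc1ccc(-c2nnc(SCCn3c([N+](=O)[O-])cnc3C)o2)c(O)c1`, in which 2-hydroxy-4-methylphenyl takes the place of 2-fluorophenyl on an aromatic carbon of the core: 2-hydroxy-4-methylphenyl in place of 2-fluorophenyl on an aromatic carbon.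

Among the measured compounds shown here, three measured steps bear on this change. Exchanging the aromatic group gave a 3.4-fold higher number from compound 1 to compound 2 (0.54 log units; beyond the scatter) and a 3.3-fold higher number from compound 1 to compound 3 (0.52 log units; beyond the scatter), both modest. Exchanging amino for fluoro gave a 1.0-fold lower number from compound 2 to compound 3 (0.02 log units; within the scatter), which lies within the scatter. The new group has a name that echoes both 2-fluorophenyl and 4-methoxyphenyl, so a value between those of the two compounds bearing them seems reasonable. For the measured compounds named here, no step clearly beyond the scatter is expected, only a lean toward lower numbers in this assay. The estimated step is a 1.7-fold lower number from compound 3 to compound 4 (0.23 log units; within the scatter). For compound 4 the expected value is 20000 nM, with an estimated range from 8000 nM to 50000 nM.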

Compound 4, half-maximal inhibitory concentration: 36700 nM
Compound 4: middle estimate off by 1.8-fold (0.26 log units), on the low side; low and high end bracket the measured number.
By their numbers in this assay, from the lowest: compound 1; then compounds 3, 2 and 4 (each within the scatter of the next).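

In this assay, 2-hydroxy-4-methylphenyl matches the two earlier groups at this position (a 1.1-fold higher number from compound 3 to compound 4 (0.04 log units; within the scatter); a 1.0-fold higher number from compound 2 to compound 4 (0.02 log units; within the scatter)). 2-Fluorophenyl, 2-aminophenyl and 2-hydroxy-4-methylphenyl therefore cannot be told apart here, even though the entering group has one more heavy atom than 2-fluorophenyl and adds a hydrogen-bond donor and acceptor. Among the compounds shown here, compound 1 with 4-methoxyphenyl remains the only clearly separate member of the set (a 3.6-fold higher number from compound 1 to compound 4 (0.56 log units; beyond the scatter)), and no available data explain this separation or the match among the other three.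

The compounds shown leave open whether the separation depends on the methoxy group itself or on where it sits. Plain phenyl, 2-methoxyphenyl and 4-hydroxyphenyl at this position could help separate those two possibilities.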